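Methyl for chloro on the core of compound 1

The compounds below may be only part of what the source reports. "The series", "measured", "known", "first", "only" and "open" are said of these compounds alone.

Compound 1 `O=C1NC(=O)C(Cc2ccc(Oc3ncc(C(F)(F)F)cc3Cl)cc2Cl)S1` is the lower of two numbers in a functional assay for agonist activity at Free fatty acid receptor 1 (Homo sapiens), read by FLIPR, in the presence of a further agent that is not named here; on this read-out higher numbers stand for an effect only at larger amounts of compound and lower numbers for an effect already at smaller amounts: in it compound 1 gives 26 nM. Among the compounds with values here, compound 2 `Cc1cccc(Oc2ccc(CC3SC(=O)NC3=O)cc2)c1C`, the only other compound measured, gives in this assay 334 nM, a gap that lies beyond the usual scatter; the two compounds differ in several places at once, so no single change can be read from this pair. Compound 3 `Cc1cc(Oc2ncc(C(F)(F)F)cc2Cl)ccc1CC1SC(=O)NC1=O` has not been measured. It differs from compound 1 in one place, (methyl in place of chloro on an aromatic carbon), on an aromatic carbon of the six-membered carbon ring that carries the (2,4-dioxo-1,3-thiazolidin-5-yl)methyl group. Within the data shown here, no measured pair shows this exact exchange, so the direction is uncertain; a step of a size within or just beyond the scatter, with a slight drift toward a higher number, is expected. Compound 3 is therefore estimated at 38 nM in this assay, within 12 nM to 120 nM, which corresponds to an expected step of a 1.5-fold higher number from compound 1 to compound 3 (0.16 log units; within the scatter).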

Compound 3, half-maximal effective concentration: 10 nM
Estimate against measurement, compound 3: 3.8-fold (0.58 log units) above, and the stated range ends above it.
By their numbers in this assay, from the lowest: compound 3; then compound 1; then compound 2.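

In this assay, placing methyl in place of chloro on the aromatic carbon ortho to the (2,4-dioxo-1,3-thiazolidin-5-yl)methyl group gives a 2.6-fold lower number from compound 1 to compound 3 (0.41 log units; beyond the scatter), a modest step that lies beyond the scatter. Within the data shown here, this is the first single-place comparison, and it shows that chloro is not required at this position for a low number: here methyl does better, which the pair of compound 1 and compound 2, differing in several places at once, could not reveal. Nothing measured here accounts for the step.

From the compounds shown here alone, it remains open whether fluoro, ethyl or methoxy at this carbon would give a lower or a higher number than methyl. Also open, going by these compounds, is whether this single exchange would give a similar step on a different background.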